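Swapping the Nitrile for a Hydroxyl on a Flat Series

The compounds below may be only part of what the source reports. "The series", "measured", "known", "first", "only" and "open" are said of these compounds alone.

Compound 3 `CN(C)c1ncnc2c1ncn2Cc1ccc(C#N)cc1` gives 0% in a functional assay on the whole organism for inhibition, with Rattus norvegicus as the target, in the maximal electroshock model, at a dose of 25 mg/kg by the intraperitoneal route (on this read-out lower numbers stand for less inhibition and higher numbers for more inhibition at the one dose given (going by the name of the read-out)), no measurable effect at this dose. Its close relatives behave the same way: compound 1 `COc1ccc(Cn2cnc3c(N(C)C)ncnc32)cc1` gives 0%, and compound 2 `CN(C)c1ncnc2c1ncn2Cc1ccc([N+](=O)[O-])cc1` gives 0%. Going by the values given here, exchanging the single group on the aromatic carbon has so far left the read-out flat: no change at the digits printed from compound 1 to compound 2 (within the scatter), no change at the digits printed from compound 1 to compound 3 (within the scatter) and no change at the digits printed from compound 2 to compound 3 (within the scatter). Compound 4 `CN(C)c1ncnc2c1ncn2Cc1ccc(O)cc1` carries the next such exchange, (hydroxy in place of cyano on an aromatic carbon). Three measured swaps at that carbon produced nothing beyond the scatter, so this one is expected to follow suit, with no change at the digits printed from compound 3 to compound 4 (within the scatter). Compound 4 is therefore estimated at 0%, with a likely range from 0% to 12%.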

Compound 4, a percentage reported as inhibition, in the whole organism at one dose (the size of the read-out at that dose, not a potency): 0%
Estimate against measurement, compound 4: no gap at the digits printed; the range from low to high includes it.
By their numbers in this assay, from the lowest: compounds 1, 2, 3 and 4 (each within the scatter of the next).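

In this assay, a hydroxy group, counted with one hydrogen-bond donor where the cyano it replaces has none, gives no change at the digits printed from compound 3 to compound 4 (within the scatter) and no change at the digits printed from compound 2 to compound 4 (within the scatter) in this series. Removing only the methyl from the oxygen gives no change at the digits printed from compound 1 to compound 4 (within the scatter) as well, so the capped and free oxygen read alike at this dose. All four groups on this aromatic carbon now stand level.

Going by these compounds, whether an amine, a carboxylic acid or a longer chain at this carbon would lift the read-out stays open, as does any change to the shared core. No measurement is at hand that explains why the series stays flat.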